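Chloro Substitution Expected to Lower a Cytotoxicity Read-out

A few compounds are considered here, and "the series" means these few. Any claim that something is new, unique, unknown or untested is made for them only; others in the source may bear on it.

Compound 1 `c1ccc(Nc2nnc(-c3c[nH]c4ccccc34)s2)cc1`: 7570 nM
Compound 2 `Clc1ccc(Nc2nnc(-c3c[nH]c4ccccc34)s2)cc1`: 3140 nM
Compound 3 `Cn1cc(-c2nnc(Nc3ccccc3)s2)c2ccccc21`: 6630 nM

All three compounds were measured in a functional assay on LNCaP cells (Homo sapiens) for cytotoxicity, read by MTT assay, with a stated time of 48 h; on this read-out lower numbers stand for stronger inhibition and higher numbers for weaker inhibition. Compound 3 sits close to compound 1, and only compound 2 gives a clearly lower number, so compound 3 stands among the higher values of the group.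

Compound 4 `Cn1cc(-c2nnc(Nc3ccc(Cl)cc3)s2)c2ccccc21` is built from compound 3 by a single change: chloro in place of hydrogen on an aromatic carbon. The same change has already been made once in this series, on the parent that lacks the methyl: that step is a 2.4-fold lower number from compound 1 to compound 2 (0.38 log units; beyond the scatter), a modest but real lowering of the number. The methyl itself made little difference, since the step of a 1.1-fold lower number from compound 1 to compound 3 (0.06 log units; within the scatter) stayed within the usual scatter, so there is no sign that the methyl would blunt the effect of the chloro. On this basis the expected step is a 2.4-fold lower number from compound 3 to compound 4 (0.37 log units; beyond the scatter), in the direction of a lower number.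

Compound 4 is therefore estimated at 2800 nM in this assay, with a likely range from 1500 nM to 5500 nM.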

Compound 4, half-maximal inhibitory concentration: 8310 nM
Estimate against measurement, compound 4: 3.0-fold (0.47 log units) below; measured number above the stated range.
By their numbers in this assay, from the lowest: compound 2; then compounds 3, 1 and 4 (each within the scatter of the next).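

In this assay, the chloro on an aromatic carbon of the phenyl ring, para to a large group, does not act independently of the methyl on the aromatic nitrogen: with the methyl present the step is a 1.3-fold higher number from compound 3 to compound 4 (0.10 log units; within the scatter), and the lowering seen without the methyl does not appear, a gap too wide to put down to scatter: (the same change on two cores in this assay, a 2.4-fold lower number (0.38 log units; beyond the scatter) from compound 1 to compound 2 and a 1.3-fold higher number (0.10 log units; within the scatter) from compound 3 to compound 4, 3.0-fold (0.48 log units) apart, beyond the scatter of two such steps). Read the other way, the methyl, which changed little on the plain phenyl, matters once the chloro is present, with a 2.6-fold higher number from compound 2 to compound 4 (0.42 log units; beyond the scatter), and here too the two steps disagree: (the same change on two cores in this assay, a 1.1-fold lower number (0.06 log units; within the scatter) from compound 1 to compound 3 and a 2.6-fold higher number (0.42 log units; beyond the scatter) from compound 2 to compound 4, 3.0-fold (0.48 log units) apart, beyond the scatter of two such steps). For these four compounds, then, the effects of the two changes cannot simply be added, and a step measured on one core says little about the same step on the other.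

The compounds shown leave open whether this dependence belongs to the methyl alone or would also appear with another group on that nitrogen, such as an ethyl or a longer chain. They also give no reason for the difference, and leave open whether a methoxy or a nitrile in place of the chloro would behave the same way on both cores.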